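A few compounds are considered here, and "the series" means these few. Any claim that something is new, unique, unknown or untested is made for them only; others in the source may bear on it.

Working notes on the series in an in vitro functional assay on HEK ts201 cells for antagonist activity at Neuronal acetylcholine receptor; alpha4/beta2 (Homo sapiens), read by fluorescence and calcium flux; a higher number here means a weaker inhibitor, a lower number a stronger inhibitor.

Compound 1 `CC1CC(=O)N(c2ccccc2C(=O)OC[C@@H]2C[C@H](c3ccccc3)CN(CCCc3ccccc3)C2)C1=O` gives 5370 nM in this assay, the lower of the two single numbers on record. Compound 2 `c1ccc(CCCN2CCCC(COCc3ccccc3-c3ccccc3)C2)cc1` gives 12600 nM in this assay, a higher number that lies beyond the scatter of the pair. Compound 3 `O=C(OCC1CCCN(C(=O)CCc2ccccc2)C1)c1ccccc1-c1ccccc1` has two entries in this assay, 5600 nM; 6030 nM (2 entries), which agree with each other within the scatter (the several entries of compound 3 in this assay, 5600 nM; 6030 nM (2 entries)).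

Compound 4 `CC1CC(=O)N(c2ccccc2C(=O)OC[C@@H]2C[C@H](C3CCCCC3)CN(CCCc3ccccc3)C2)C1=O` is not yet measured. Relative to compound 1 it carries the change (cyclohexyl in place of phenyl on a saturated ring carbon), cyclohexyl in place of phenyl on a saturated ring carbon. Within the data shown here, no measured pair covers a change of this kind, so the expectation rests on compound 1 alone; the step of a 1.0-fold higher number from compound 1 to compound 4 (0.01 log units; within the scatter) is expected to be small, in no settled direction, and not clearly beyond the scatter. Compound 4 is estimated at 5500 nM, within 2000 nM to 14000 nM.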

Compound 4, half-maximal inhibitory concentration: 39800 nM
Compound 4: middle estimate off by 7.2-fold (0.86 log units), on the low side, outside the stated range (above it).
By their numbers in this assay, from the lowest: compound 1; then compound 2; then compound 4.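

At this saturated ring carbon, two ring bonds from the ring nitrogen, cyclohexyl does not stand in for phenyl in this assay: with the same count of heavy atoms, the change gives a 7.4-fold higher number from compound 1 to compound 4 (0.87 log units; beyond the scatter). Among these compounds, this is the only measured step between compounds differing in one place, and it shows that this position responds to the nature of the ring it carries. Nothing on record bears on the cause of the step.

On these data alone, it remains open whether a pyridyl ring or a methyl group at this carbon would stay closer to compound 1 or fall nearer compound 4. As far as these compounds go, whether the step would carry over to other compounds also remains open.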